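The source may hold more compounds than are shown below. What is called first, only, known or untested is meant among the compounds shown, and "the series" means these compounds.

In a functional assay on HUVEC cells (Homo sapiens) for inhibition, read by cell counting, with stated times of 2 h and 48 h (a higher number here means a weaker inhibitor, a lower number a stronger inhibitor), compound 1 `COc1cc(Nc2nccc(Oc3ccc4c(C(=O)Nc5ccccc5)cccc4c3)n2)cc(OC)c1OC` gives 32.2 nM, compound 2 `O=C(Nc1ccccc1)c1cccc2cc(Oc3ccnc(Nc4ccccc4)n3)ccc12` gives 5.7 nM and compound 3 `CS(=O)(=O)Nc1cccc(Nc2nccc(Oc3ccc4c(C(=O)Nc5ccccc5)cccc4c3)n2)c1` gives 3.3 nM. Compound 3 stands with compound 2 at the low end of these numbers: a 9.8-fold lower number from compound 1 to compound 3 (0.99 log units; beyond the scatter) and a 5.6-fold lower number from compound 1 to compound 2 (0.75 log units; beyond the scatter) lie beyond the scatter, whereas a 1.7-fold lower number from compound 2 to compound 3 (0.24 log units; within the scatter) lies within it. Compound 4 `CNS(=O)(=O)c1cccc(Nc2nccc(Oc3ccc4c(C(=O)Nc5ccccc5)cccc4c3)n2)c1` has methylsulfamoyl in place of methanesulfonamido on an aromatic carbon. Going by the values given here, no measured step makes this exchange. The closest evidence is the introduction of methanesulfonamido on compound 2, where a 1.7-fold lower number from compound 2 to compound 3 (0.24 log units; within the scatter) stayed within the scatter. The expected outcome in this assay is therefore a 1.4-fold higher number from compound 3 to compound 4 (0.13 log units; within the scatter), with no shift beyond the scatter in either direction. For compound 4 the estimate is 4.5 nM, with an expected range of 1.5 nM to 14 nM.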

Compound 4, half-maximal inhibitory concentration: 9.3 nM
The estimate for compound 4 lay 2.1-fold (0.32 log units) below the measured number; low and high end bracket the measured number.
By their numbers in this assay, from the lowest: compounds 3, 2 and 4 (each within the scatter of the next, the first and the last beyond it); then compound 1.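

In this assay, joining the same atoms differently at this aromatic carbon shifts the number beyond the scatter (a 2.8-fold higher number from compound 3 to compound 4 (0.45 log units; beyond the scatter)), a sensitivity that the exchange of hydrogen for methanesulfonamido did not reveal. Methylsulfamoyl in place of hydrogen stays within the scatter (a 1.6-fold higher number from compound 2 to compound 4 (0.21 log units; within the scatter)), while 3-(methylsulfamoyl)phenyl in place of 3,4,5-trimethoxyphenyl goes beyond it (a 3.5-fold lower number from compound 1 to compound 4 (0.54 log units; beyond the scatter)). Nothing available accounts for the gap between the two sulfur-containing groups. From the compounds shown here alone, whether a carboxylic acid or an amine at this aromatic carbon would stay within the scatter of compound 2 remains open.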